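Swapping methoxy for chloro on an antiproliferative series

A few compounds are considered here, and "the series" means these few. Any claim that something is new, unique, unknown or untested is made for them only; others in the source may bear on it.

Measured in a functional assay on A549 cells (Homo sapiens) for antiproliferative activity, read by MTT assay, with a stated time of 48 h; a lower number here means a stronger inhibitor, a higher number a weaker inhibitor:
- compound 1 `Oc1ccc2ccccc2c1C(Nc1nc2ccccc2s1)c1cn(-c2ccccc2)nc1-c1ccccc1` gives 36200 nM
- compound 2 `COc1cccc(-c2nn(-c3ccccc3)cc2C(Nc2nc3ccccc3s2)c2c(O)ccc3ccccc23)c1` gives 24800 nM

Compound 2, at 24800 nM, cannot be separated from compound 1 on these numbers. Compound 3 `Oc1ccc2ccccc2c1C(Nc1nc2ccccc2s1)c1cn(-c2ccccc2)nc1-c1cccc(Cl)c1` follows from compound 2 by one change: chloro in place of methoxy on an aromatic carbon. For the measured compounds named here, the only measured step that bears on this is a 1.5-fold lower number from compound 1 to compound 2 (0.16 log units; within the scatter), which introduced that methoxy. Chloro itself remains untested, so no step beyond the scatter is expected in this assay. The estimate amounts to a 1.0-fold higher number from compound 2 to compound 3 (0.02 log units; within the scatter), an expected step within the scatter. Compound 3 is expected at 26000 nM, with an estimated range of 12000 nM to 55000 nM.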

Compound 3, half-maximal inhibitory concentration: 20400 nM
Compound 3: middle estimate off by 1.3-fold (0.11 log units), on the high side, within the range that was stated.
By their numbers in this assay, from the lowest: compounds 3, 2 and 1 (each within the scatter of the next).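

In this assay the change from 3-methoxyphenyl to 3-chlorophenyl reads as a 1.2-fold lower number from compound 2 to compound 3 (0.08 log units; within the scatter) and leaves the two groups inseparable at this position. The hydrogen-to-chloro comparison reads as a 1.8-fold lower number from compound 1 to compound 3 (0.25 log units; within the scatter), so chloro, like methoxy, gives no step beyond the scatter here. Nothing measured gives a reason for these values. As far as these compounds go, whether an amine or a carboxylic acid on this same aromatic carbon would give a step beyond the scatter remains open.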